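A few compounds are considered here, and "the series" means these few. Any claim that something is new, unique, unknown or untested is made for them only; others in the source may bear on it.

Working notes on the series.

Of the compounds shown here, three have numbers so far. Compound 1 `Nc1ccccc1NC(=O)c1ccc(CSC(=S)N2CCN(Cc3ccccn3)CC2)cc1` gives 82.4% in a functional assay on A-375 cells (Homo sapiens) for antiproliferative activity, read by CCK-8 assay, with a stated time of 72 h, tested at 8 uM; a lower number here means a weaker effect, a higher number a stronger effect of the compound at the concentration tested. Compound 2 `CC1CCCCN1C(=S)SCc1ccc(C(=O)Nc2ccccc2N)cc1` gives 85.2% in this assay, the highest of the three numbers, though its nearest neighbour, compound 1, sits within the scatter of it, so no order between the two can be claimed. Compound 3 `Nc1ccccc1NC(=O)c1ccc(CSC(=S)N2CCc3ccc([N+](=O)[O-])cc32)cc1` gives 42% in this assay, well beyond the scatter below compound 2. Within the data shown here, no two of the measured compounds differ in a single place, so no single-change step has been measured yet.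

Compound 4 `CC1CCN(C(=S)SCc2ccc(C(=O)Nc3ccccc3N)cc2)CC1` is the next member to be measured in this assay. It differs from compound 2 in one place only: 4-methylpiperidin-1-yl in place of 2-methylpiperidin-1-yl on a thiocarbonyl carbon The change keeps the ring and the atom count unchanged and moves the methyl within the ring. With no measured step of this kind in the series, the expectation rests on compound 2 alone. For the step from compound 2 to compound 4, no change beyond the scatter is expected; a small drift in either direction would be consistent with the usual variation of this read-out. The estimate for compound 4 is therefore 82% in this assay, with a range from 68% to 92%, corresponding to an expected step of a number 3.2 percentage points lower from compound 2 to compound 4 (within the scatter).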

Compound 4, a percentage reported as inhibition, at one concentration (the size of the read-out at that concentration, not a potency): 87.4%
The estimate for compound 4 lay 5.4 percentage points below the measured number; low and high end bracket the measured number.
By their numbers in this assay, from the lowest: compound 3; then compounds 1, 2 and 4 (each within the scatter of the next).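

Among these compounds, the swap of 2-methylpiperidin-1-yl for 4-methylpiperidin-1-yl on a thiocarbonyl carbon is the first single-change step, and in this assay it amounts to a number 2.2 percentage points higher from compound 2 to compound 4 (within the scatter). At this place, then, two arrangements of the same atoms cannot be told apart by this read-out, so the methyl group's location on the piperidine shows no effect here, and no order can be claimed between compound 2 and compound 4. Nothing measured on these compounds speaks to the reason for this result.

As far as these compounds go, the step covers only these two methyl placements, so it remains open how the read-out would respond at this place to 3-methylpiperidin-1-yl, to unsubstituted piperidin-1-yl, or to a longer chain such as 4-ethylpiperidin-1-yl. From the compounds shown here alone, because the read-out is taken at one concentration, it also remains open whether compound 2 and compound 4 would still read alike at lower concentrations, where a difference hidden at the tested concentration could appear.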